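Lengthening the Chain of Compound 2

The compounds below may be only part of what the source reports. "The series", "measured", "known", "first", "only" and "open" are said of these compounds alone.

In a functional assay, read by spectrophotometry, with a stated time of 6 min (a higher number here means a weaker inhibitor, a lower number a stronger inhibitor), compound 2 (`CCCCCCOc1cc(OC)ccc1C(C)=O`) gives 42100000 nM. Compound 1 (`CCCCCCCCOc1cc(OC)c(Br)cc1C(C)=O`) gives 32000000 nM. Going by the values given here, these two values lie within the usual scatter of each other, so compound 2 cannot be separated from the only other measured compound.

Compound 3 (`CCCCCCCCOc1cc(OC)ccc1C(C)=O`) has not yet been measured. It differs from compound 2 by ethyl in place of hydrogen on a saturated chain carbon, six bonds along the chain from an oxygen on an aromatic ring.

Among the compounds with values here, no measured pair shows the size of this change on its own, so the data offer no direct guide. Within the data shown here, with compound 1 at 32000000 nM as the only other number available, a small shift toward a lower number in this assay is expected, with nothing beyond the scatter. The expected change, a 1.4-fold lower number from compound 2 to compound 3 (0.15 log units; within the scatter), is an estimate that stays within that scatter. For compound 3 the estimated value is 30000000 nM, with an expected range from 13000000 nM to 65000000 nM.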

Compound 3, half-maximal inhibitory concentration: 38300000 nM
Beside the measured number, compound 3's estimate is 1.3-fold (0.11 log units) below it; the measured number falls inside the stated range.
By their numbers in this assay, from the lowest: compounds 1, 3 and 2 (each within the scatter of the next).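

In this assay, going by these compounds alone, ethyl in place of hydrogen on a saturated chain carbon, six bonds along the chain from an oxygen on an aromatic ring, gives a 1.1-fold lower number from compound 2 to compound 3 (0.04 log units; within the scatter), so the first direct reading of this change at this position shows no step beyond the scatter. Within the data shown here, compound 3 also isolates the bromo group of compound 1 for the first time: hydrogen in place of bromo on an aromatic carbon gives a 1.2-fold higher number from compound 1 to compound 3 (0.08 log units; within the scatter), and this step likewise stays within the scatter. No other information bears on these results.

The compounds shown leave open whether a longer chain than that of compound 3, or a chain ending in an amine or a carboxylic acid, would give a number in this assay that separates from these three. They also leave open whether a nitrile on the aromatic carbon that carries bromo in compound 1 would give a step beyond the scatter.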